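Nitro for chloro in compound 1

A few compounds are considered here, and "the series" means these few. Any claim that something is new, unique, unknown or untested is made for them only; others in the source may bear on it.

compound 1 `O=C(/C=C/c1ccc(Cl)cc1)c1ccccc1O`: 48900 nM
compound 2 `O=C(/C=C/c1ccccc1Cl)c1ccccc1O`: 7600 nM

In a functional assay on WM-115 cells (Homo sapiens) for cytotoxicity, read by MTT assay (on this read-out higher numbers stand for weaker inhibition and lower numbers for stronger inhibition), compound 1 stands highest of the two, and the gap down to compound 2 lies beyond the usual scatter. Compound 3 `O=C(/C=C/c1ccc([N+](=O)[O-])cc1)c1ccccc1O` keeps the core of compound 1 but has nitro in place of chloro on an aromatic carbon, para to a large group: nitro in place of chloro on an aromatic carbon. Among the measured compounds shown here, no measured pair shows this change. With compound 1 at 48900 nM, the higher of the two numbers, a small step to a lower number is expected, about the size of the scatter. The expected step is a 2.0-fold lower number from compound 1 to compound 3 (0.29 log units; within the scatter). For compound 3 the estimated value is 25000 nM, with an expected range of 8000 nM to 80000 nM.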

Compound 3, half-maximal inhibitory concentration: 27600 nM
Compound 3: the middle estimate sits 1.1-fold (0.04 log units) below what was measured; measured number inside the range.
By their numbers in this assay, from the lowest: compound 2; then compounds 3 and 1 (each within the scatter of the next).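

Nitro in place of chloro on an aromatic carbon, para to a large group, gives a 1.8-fold lower number from compound 1 to compound 3 (0.25 log units; within the scatter) in this assay, so at this position the two groups are not told apart, although nitro carries hydrogen-bond acceptors and chloro none. Going by these compounds, whether an amine or a carboxylic acid at this position would also stay within the scatter of compound 1 remains open, as does whether nitro would match chloro on the core of compound 2. Nothing available here speaks to why these two groups read alike.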